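Swapping chloro for methoxy and checking whole-animal tolerance

A few compounds are considered here, and "the series" means these few. Any claim that something is new, unique, unknown or untested is made for them only; others in the source may bear on it.

Compound 3 `C/C(C(=O)NC1CC1)=C(/C)c1ccc(Cl)cc1` was tested in a toxicity assay on the whole organism (strain Icem-CET (SPF Caw)) for cytotoxicity, with Mus musculus as the target; on this read-out higher numbers stand for an effect only at larger amounts of compound and lower numbers for an effect already at smaller amounts. Compound 3 gives 150 mg/kg, level with compound 2 `C#CCNC(=O)/C(C)=C(\C)c1ccc(OC)cc1`, which gives 150 mg/kg, and the two sit together at the low end of the three numbers. Compound 1 `COc1ccc(/C(C)=C(/C)C(=O)NC2CC2)cc1` gives 300 mg/kg, a difference that stays within the scatter. Compound 4 `COc1ccc(/C(C)=C(\C)C(=O)NC2CC2)cc1` has not yet been tested in this assay. The change is methoxy in place of chloro on an aromatic carbon. Going by the values given here, no measured pair isolates this swap, so only a modest shift in this assay is expected, if any beyond the scatter. Compound 4 is estimated at 220 mg/kg, with a range from 120 mg/kg to 450 mg/kg, partly because compound 1 also carries a methoxy group and gives 300 mg/kg. The expected step is a 1.5-fold higher number from compound 3 to compound 4 (0.17 log units; within the scatter).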

Compound 4, dose for half-maximal effect: 250 mg/kg
Beside the measured number, compound 4's estimate is 1.1-fold (0.06 log units) below it, within the range that was stated.
By their numbers in this assay, from the lowest: compounds 2, 3, 4 and 1 (each within the scatter of the next).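

In this assay, methoxy in place of chloro on the aromatic carbon gives a 1.7-fold higher number from compound 3 to compound 4 (0.22 log units; within the scatter), so this swap alone shows no separable shift on this read-out. Cyclopropyl in place of propargyl on the amide-type nitrogen gives a 1.7-fold higher number from compound 2 to compound 4 (0.22 log units; within the scatter), and the geometry of the double bond gives a 1.2-fold lower number from compound 1 to compound 4 (0.08 log units; within the scatter), so neither of these changes separates from the scatter either. The last comparison isolates geometry alone: the fact that compounds 1 and 4 differ only in the configuration as drawn

As far as these compounds go, whether an amine or a carboxylic acid on that aromatic carbon, or a longer chain on the amide-type nitrogen, would move the number beyond the scatter remains open.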